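Aryl replacement of the triflate in a 5-HT1B indole series

The compounds below may be only part of what the source reports. "The series", "measured", "known", "first", "only" and "open" are said of these compounds alone.

Measured compounds:
- compound 1 `Cc1[nH]c2ccc(Br)cc2c1C1=CCNCC1`: 75 nM
- compound 2 `Cc1[nH]c2ccc(F)cc2c1C1=CCNCC1`: 200 nM
- compound 3 `Cc1[nH]c2ccc(OS(=O)(=O)C(F)(F)F)cc2c1C1=CCNCC1`: 29 nM

In an assay on isolated protein for displacement of a labelled ligand from 5-hydroxytryptamine receptor 1B (Rattus norvegicus) (on this read-out lower numbers stand for stronger inhibition and higher numbers for weaker inhibition), compound 3 gives 29 nM, the lowest of the three numbers; compound 1 lies nearest with 75 nM and compound 2 furthest with 200 nM. The change a 2.6-fold lower number from compound 1 to compound 3 (0.41 log units; beyond the scatter) and the change a 6.9-fold lower number from compound 2 to compound 3 (0.84 log units; beyond the scatter) are both beyond the scatter, and a 2.7-fold higher number from compound 1 to compound 2 (0.43 log units; beyond the scatter) as well, so the substituent on this carbon matters for this assay across these three compounds.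

Compound 4 `Cc1[nH]c2ccc(-c3ccsc3)cc2c1C1=CCNCC1` carries thiophen-3-yl in place of ((trifluoromethyl)sulfonyl)oxy on an aromatic carbon. Among the measured compounds shown here, no measured step swaps the ((trifluoromethyl)sulfonyl)oxy group for an aromatic ring, so the three measured steps bear on it only indirectly: they show that this carbon tolerates groups of quite different size without loss, and the larger groups gave the lower numbers, compound 2 being the exception with the smallest group and the highest number. On that basis a step within the scatter or a modest lowering is expected, a 1.2-fold lower number from compound 3 to compound 4 (0.06 log units; within the scatter). For compound 4 the estimate is 25 nM, with a range from 7 nM to 90 nM.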

Compound 4, half-maximal inhibitory concentration: 12 nM
Beside the measured number, compound 4's estimate is 2.1-fold (0.32 log units) above it, and the stated range covers the measured number.
By their numbers in this assay, from the lowest: compound 4; then compound 3; then compound 1; then compound 2.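

In this assay, an aromatic ring on this carbon not only holds the binding seen with the earlier groups but improves on it, with a 2.4-fold lower number from compound 3 to compound 4 (0.38 log units; beyond the scatter). Thiophen-3-yl has fewer heavy atoms than the ((trifluoromethyl)sulfonyl)oxy group it replaces, so the order of numbers no longer follows group size alone; compound 4 goes against the trend suggested by compounds 1, 2 and 3. Among the compounds shown here, the ring also improves on both halogens, with a 6.3-fold lower number from compound 1 to compound 4 (0.80 log units; beyond the scatter) and a 17-fold lower number from compound 2 to compound 4 (1.22 log units; beyond the scatter), the latter being the only large step in the set, and nothing available explains these changes.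

Whether the sulfur atom matters remains open, since phenyl, furan-3-yl and thiophen-2-yl do not appear among these compounds. Also open, as far as these compounds go, is how an amine or a carboxylic acid carried on the ring would shift the number.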